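Biaryl sulfonamides: exchanging the second aromatic ring

A few compounds are considered here, and "the series" means these few. Any claim that something is new, unique, unknown or untested is made for them only; others in the source may bear on it.

Compound 3 `CC1CCN(C2CCN(S(=O)(=O)c3cccc(-c4ccccc4C(F)(F)F)c3)CC2)CC1` gives 10 nM in a functional assay on DLD-1 cells (Homo sapiens) for antiproliferative activity, read by CellTiter-Glo, with a stated time of 72 h (on this read-out higher numbers stand for weaker inhibition and lower numbers for stronger inhibition), the lowest of the two numbers in the set. Its nearest neighbour is compound 1 `COc1ccc(-c2cccc(S(=O)(=O)N3CCC(N4CCC(C)CC4)CC3)c2)cc1`, which in this assay gives 23 nM; the step of a 2.3-fold lower number from compound 1 to compound 3 (0.36 log units; beyond the scatter) is modest but beyond the scatter. Compound 2 `COc1cccc(S(=O)(=O)N2CCC(N3CCC(C)CC3)CC2)c1` is the one entry that sits at the limit of > 5000 nM in this assay, at which 1 of the 3 values shown sits. For compound 2 the result in this assay is reported only as a limit, > 5000 nM, not as a number. The two steps that involve this limit, an at least 210-fold higher number from compound 1 to compound 2 (2.33 log units; beyond the scatter) and an at least 500-fold lower number from compound 2 to compound 3 (2.69 log units; beyond the scatter), are both large: a far weaker result accompanies loss of the second aromatic ring in these three compounds.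

Compound 4 `Cc1ccc(-c2cccc(S(=O)(=O)N3CCC(N4CCC(C)CC4)CC3)c2)cc1` differs from compound 3 as follows: 4-methylphenyl in place of 2-(trifluoromethyl)phenyl on an aromatic carbon. Within the data shown here, the only measured step that compares one aromatic ring with another in this position is a 2.3-fold lower number from compound 1 to compound 3 (0.36 log units; beyond the scatter), which is small. The 4-methylphenyl of compound 4 differs from the 4-methoxyphenyl of compound 1 only in the substituent on the ring, so a number between those of compound 1 and compound 3 is the working assumption. The step of a 2.0-fold higher number from compound 3 to compound 4 (0.30 log units; within the scatter) is therefore expected to be modest, toward a higher number. Compound 4 is estimated at 20 nM, with a range of 8 nM to 50 nM.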

Compound 4, half-maximal inhibitory concentration: 11 nM
Compound 4: the middle estimate sits 1.8-fold (0.26 log units) above what was measured, within the range that was stated.
By their numbers in this assay, from the lowest: compounds 3 and 4 (each within the scatter of the next); then compound 1. At a limit, above all of these: compound 2.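

In this assay, the 4-methylphenyl and 2-(trifluoromethyl)phenyl groups cannot be told apart on this aromatic carbon: the step of a 1.1-fold higher number from compound 3 to compound 4 (0.04 log units; within the scatter) lies within the scatter, so among the compounds shown, trifluoromethyl is not required for a result at this level. Among these compounds, the step of a 2.1-fold lower number from compound 1 to compound 4 (0.32 log units; beyond the scatter) is the first change confined to the substituent on the second ring, methyl in place of methoxy, and it is modest but beyond the scatter, far smaller than the steps that accompany loss of that ring. Compound 2 is known only at a limit, so the large step of an at least 450-fold lower number from compound 2 to compound 4 (2.65 log units; beyond the scatter) gives a minimum size and not an exact one: the limit of > 5000 nM in this assay, at which 1 of the 4 values shown sits.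

No pair shown carries the same substituent at two places on the second ring, so the place of a substituent and its identity cannot be separated. Also open, from the compounds shown here alone, is whether numbers of this order survive with an amine or a carboxylic acid on that ring, or with a pyridine ring in its stead.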